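A relocated bromine: compound 1 to compound 4

The compounds below may be only part of what the source reports. "The series", "measured", "known", "first", "only" and "open" are said of these compounds alone.

In a functional assay on KG-1 cells (Homo sapiens) for cytotoxicity, read by luminescence and CellTiter-Glo, with a stated time of 3 days (a lower number here means a stronger inhibitor, a higher number a weaker inhibitor), compound 1 (`O=C(Nc1cc(C(F)(F)F)cc(C(F)(F)F)c1)c1ccc(Br)cc1O`) gives 830 nM. Compound 3 (`O=C(Nc1cc(C(F)(F)F)cc(C(F)(F)F)c1)c1ccc(-c2ccccc2)cc1O`) gives 860 nM, which is within the scatter of that number. Compound 2 (`N#Cc1cc(Cl)ccc1NC(=O)c1ccc2cccnc2c1O`) gives 3540 nM, a number beyond the scatter from that of compound 1. Compound 1 and compound 3 thus share the low end of the three numbers, and compound 2 stands apart.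

Compound 4 (`O=C(Nc1cc(C(F)(F)F)cc(C(F)(F)F)c1)c1cc(Br)ccc1O`) has the same atoms as compound 1, joined differently: 5-bromo-2-hydroxyphenyl in place of 4-bromo-2-hydroxyphenyl on a carbonyl carbon. In words, 5-bromo-2-hydroxyphenyl stands in place of 4-bromo-2-hydroxyphenyl on a carbonyl carbon.

Within the data shown here, only one measured step touches this bromo group. With phenyl in place of bromo on an aromatic carbon, it is a 1.0-fold higher number from compound 1 to compound 3 (0.02 log units; within the scatter). Among the measured compounds shown here, no measured pair shows the bromo group moved, so this evidence is indirect. For the measured compounds named here, with that single step as the only guide, no change beyond the scatter is expected in this assay, and neither direction is favoured. The estimated step is a 1.1-fold lower number from compound 1 to compound 4 (0.04 log units; within the scatter). For compound 4 the estimated value is 750 nM, with an expected range from 280 nM to 2000 nM.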

Compound 4, half-maximal inhibitory concentration: 300 nM
Estimate against measurement, compound 4: 2.5-fold (0.40 log units) above; measured number inside the range.
By their numbers in this assay, from the lowest: compound 4; then compounds 1 and 3 (each within the scatter of the next); then compound 2.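

In this assay, 5-bromo-2-hydroxyphenyl in place of 4-bromo-2-hydroxyphenyl on a carbonyl carbon gives a step beyond the scatter (a 2.8-fold lower number from compound 1 to compound 4 (0.44 log units; beyond the scatter)), so the place of the bromine on this ring matters even though the atoms stay the same. The earlier step (a 1.0-fold higher number from compound 1 to compound 3 (0.02 log units; within the scatter)) exchanged the bromine for phenyl without leaving the scatter, and taken alone it gave no sign that this ring was sensitive to change; the new step, though modest, is the first among these compounds to show such sensitivity. No measurement of any property is at hand that accounts for the shift.

The compounds shown leave open whether the lower number belongs to bromine itself or to any group in the place it takes in compound 4, such as phenyl, methoxy or an amine. Among these compounds, they also leave open whether the same relocation would have a like effect with an amide partner other than the one in compound 1, or with a carboxylic acid on the ring.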